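The source may hold more compounds than are shown below. What is called first, only, known or untested is meant among the compounds shown, and "the series" means these compounds.

Working notes on the series.

Of the compounds shown here, three have been measured in an assay on isolated protein for agonist activity at Free fatty acid receptor 1 (Homo sapiens); on this read-out higher numbers stand for an effect only at larger amounts of compound and lower numbers for an effect already at smaller amounts. Compound 1 `CC#CC(CC(=O)O)c1ccc(OCc2ccc3nc(-c4ccccc4)cn3c2)cc1` gives 979 nM. Compound 2 `CC#CC(CC(=O)O)c1ccc(OCc2ccc3nc(-c4ccc(F)cc4)cn3c2)cc1` gives 623 nM. Compound 3 `CC#CC(CC(=O)O)c1ccc(OCc2ccn3cc(-c4ccc(F)cc4F)nc3c2)cc1` gives 792 nM.

Compounds 1 and 2 share a core and differ in one place, (hydrogen in place of fluoro on an aromatic carbon). The step is a 1.6-fold higher number from compound 2 to compound 1 (0.20 log units; within the scatter). Compounds 2 and 3 carry different cores; the difference between the two cores is not broken down here. Their values in this assay lie within the scatter of each other, as do those of compound 3 and compound 1.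

Compound 4 `CC#CC(CC(=O)O)c1ccc(OCc2ccn3cc(-c4ccc(F)cc4)nc3c2)cc1` is not yet measured. It differs from compound 3 in one place, (hydrogen in place of fluoro on an aromatic carbon). This is the same kind of change as that from compound 2 to compound 1, but not the same: in the earlier pair the fluoro sits para to a large group, whereas here it sits ortho to a large group and meta to a fluoro group, and the larger reading is 2,4-difluorophenyl to 4-fluorophenyl rather than 4-fluorophenyl to phenyl.

In this assay the step from compound 3 to compound 4 is expected to be a 1.1-fold higher number from compound 3 to compound 4 (0.03 log units; within the scatter), beside the earlier 1.6-fold higher number from compound 2 to compound 1 (0.20 log units; within the scatter); this rests on the one measured occurrence of this kind of change, which stayed within the scatter, and on the differing surroundings of the place, which leave the direction open. For compound 4 the expected value is 850 nM, estimated between 400 nM and 1800 nM.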

Compound 4, half-maximal effective concentration: 783 nM
Estimate against measurement, compound 4: 1.1-fold (0.04 log units) above; the measured number falls inside the stated range.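

Hydrogen in place of fluoro on the core of compound 3, the change from 2,4-difluorophenyl to 4-fluorophenyl, gives in this assay a 1.0-fold lower number from compound 3 to compound 4 (0.00 log units; within the scatter). Set beside the same kind of change on the core of compound 1, the two steps cannot be told apart, and within this pair of cores the change carries over without a detectable difference: the same change on two cores in this assay, a 1.6-fold higher number (0.20 log units; within the scatter) from compound 2 to compound 1 and a 1.0-fold lower number (0.00 log units; within the scatter) from compound 3 to compound 4, 1.6-fold (0.20 log units) apart, within the scatter of two such steps. Among the compounds shown here, this does not show that the change is without effect in general or that the two cores respond alike, since only two steps are available, neither step lies beyond the scatter, and the fluoro leaves a different place in each pair, so the comparison is not one of an identical site on two cores.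

Still open, going by these compounds, is how a phenyl carrying no fluoro on the core of compound 3, or a 2,4-difluorophenyl on the core of compound 1, would read in this assay, either of which would allow a closer comparison of the two cores. Also open, on these data alone, is whether a larger or differently built group at the same place, such as chloro, methoxy or a nitrile, would move the number beyond the scatter on either core.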